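This account rests on a few compounds, and the source may have more. Where it says the series, first, only, none or still open, it means among the compounds named here.

Measured compounds in a functional assay on DLD-1 cells (Homo sapiens) for cytotoxicity, with a stated time of 48 h; on this read-out lower numbers stand for stronger inhibition and higher numbers for weaker inhibition:

Compound 1 `COc1cccc2c(=O)cc(/C=C/[S+](C)[O-])oc12` gives 9000 nM.
Compound 2 `C[S+]([O-])/C=C/c1cc(=O)c2ccccc2o1` gives 8000 nM.
Compound 3 `COc1ccc2c(=O)cc(/C=C/[S+](C)[O-])oc2c1` gives 7800 nM.

Compound 2 holds the second highest of the three numbers, its nearest neighbour being compound 3 and the furthest compound 1, with both gaps within the scatter. The next compound, compound 4 `COc1ccc2oc(/C=C/[S+](C)[O-])cc(=O)c2c1`, has not yet been measured. It differs from compound 2 in one place: methoxy in place of hydrogen on an aromatic carbon.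

For the measured compounds named here, two measured steps bear on this change, since both also put a methoxy on an aromatic carbon of the shared core or remove one: a 1.1-fold lower number from compound 1 to compound 2 (0.05 log units; within the scatter) and a 1.0-fold lower number from compound 2 to compound 3 (0.01 log units; within the scatter). Neither moved the number beyond the scatter, so a methoxy at the two places already tried has left this read-out essentially unchanged. On that basis the methoxy in compound 4 is expected to produce no step beyond the scatter either, with no preferred direction: the estimated step is no change at the digits printed from compound 2 to compound 4 (within the scatter). The number for compound 4 in this assay is therefore estimated at 8000 nM, with a range from 4000 nM to 16000 nM.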

Compound 4, half-maximal inhibitory concentration: 5700 nM
Compound 4: the middle estimate sits 1.4-fold (0.15 log units) above what was measured; the measured number falls inside the stated range.
By their numbers in this assay, from the lowest: compounds 4, 3, 2 and 1 (each within the scatter of the next).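

In this assay, methoxy at this third place, on the six-membered aromatic ring of carbon only, meta to a fused ring and para to a fused ring, gives a 1.4-fold lower number from compound 2 to compound 4 (0.15 log units; within the scatter). This step is within the scatter, so all three methoxy placements shown now stay within the scatter of the hydrogen of compound 2, and this position does not separate itself from the two tried before. Nothing measured here bears on the reason for this flat response.

Going by these compounds, whether a different group at this position, such as an amine, a carboxylic acid or a longer alkoxy chain, would move the number beyond the scatter remains open. Also open, on these data alone, is whether two methoxy groups together on the shared core would do so.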